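This account rests on a few compounds, and the source may have more. Where it says the series, first, only, none or still open, it means among the compounds named here.

Measured in an ADME assay on cells (Peritoneal macrophage, Mus musculus) for cytotoxicity, read by MTT assay, with a stated time of 24 h; a higher number here means that more compound is tolerated, a lower number that less compound is tolerated:
Compound 1 `O=C(/N=C(/NCc1ccccc1)Nc1ccccc1)c1ccccc1`: 35900 nM
Compound 2 `O=C(/N=C(/NCc1ccccc1)Nc1ccc(I)cc1)c1ccccc1`: 619000 nM

Of these two compounds, compound 2 holds the higher number, 619000 nM, so more of it is tolerated. Compound 3 `O=C(/N=C(/NCc1ccccc1)Nc1ccc(Cl)cc1)c1ccccc1` has not yet been measured. It differs from compound 2 by chloro in place of iodo on an aromatic carbon. Within the data shown here, one measured step bears on this change: a 17-fold higher number from compound 1 to compound 2 (1.24 log units; beyond the scatter), a large step made by iodo in place of hydrogen on an aromatic carbon. Among the measured compounds shown here, no chloro compound has been measured, so the data offer only hydrogen and iodo as reference points. Compound 3 is therefore expected to fall between compound 1 and compound 2, nearer neither end with any certainty. In this assay the expected change is a 4.1-fold lower number from compound 2 to compound 3 (0.62 log units; beyond the scatter), downward and smaller than the measured step. For compound 3 the estimated value is 150000 nM, with an expected range of 45000 nM to 500000 nM.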

Compound 3, half-maximal cytotoxic concentration: 827000 nM
Estimate against measurement, compound 3: 5.5-fold (0.74 log units) below; measured number above the stated range.
By their numbers in this assay, from the lowest: compound 1; then compounds 2 and 3 (each within the scatter of the next).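

In this assay, the exchange of iodo for chloro on this aromatic carbon reads as a 1.3-fold higher number from compound 2 to compound 3 (0.13 log units; within the scatter), so the two halogens are not separated at this position. Chloro in place of hydrogen reads as a 23-fold higher number from compound 1 to compound 3 (1.36 log units; beyond the scatter), which shows that the large step is not confined to iodo: with either halogen in the 4-position of the phenyl group, the compound stands well apart from compound 1. No measurement at hand offers an explanation for this result.

Whether any group on this carbon would do the same remains open, since only hydrogen and two halogens are shown. A methoxy group, an amine or a carboxylic acid here could show whether the step belongs to halogens or to replacing hydrogen at all.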